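Working notes on a four-compound series, one core

The source may hold more compounds than are shown below. What is called first, only, known or untested is meant among the compounds shown, and "the series" means these compounds.

The read-out throughout is a functional assay on the whole organism with Rattus norvegicus as the target, at a dose of 40 mg/kg by the intraperitoneal route; on this read-out higher numbers stand for more inhibition at the one dose given (going by the name of the read-out) and lower numbers for less inhibition. Measured so far:

compound 1, `CCCc1nc2c(OCc3ccccc3)cccn2c1N`, gives 31%
compound 2, `CCCCc1nc2c(OCc3ccccc3)cccn2c1N`, gives 26%
compound 3, `CNc1c(C)nc2c(OCc3ccccc3)cccn12`, gives 55%

Compound 1 and compound 2 share a core and differ by methyl in place of hydrogen on a saturated chain carbon, three bonds along the chain from an aromatic carbon; the step is a number 5 percentage points lower from compound 1 to compound 2 (within the scatter). Compound 3 stands highest of the three, and its steps to compound 1 and to compound 2 both lie beyond the scatter. The difference between the core of compound 3 and the core of compound 1 is not broken down here.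

Compound 4, `CCNc1c(C)nc2c(OCc3ccccc3)cccn12`, is not yet measured. It differs from compound 3 by methyl in place of hydrogen on a saturated chain carbon bound to a nitrogen on an aromatic ring. This is the same kind of change as that from compound 1 to compound 2, but not the same: there the place was on a saturated chain carbon, three bonds along the chain from an aromatic carbon, whereas here it is on a saturated chain carbon bound to a nitrogen on an aromatic ring. For the measured compounds named here, the only precedent is the small step of a number 5 percentage points lower from compound 1 to compound 2 (within the scatter), so for compound 4 a step of about a number 5 percentage points lower from compound 3 to compound 4 (within the scatter) in this assay is expected, resting on compound 3 at 55%. The estimate for compound 4 is therefore 50%, with a range from 30% to 70%.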

Compound 4, a percentage reported as inhibition, in the whole organism at one dose (the size of the read-out at that dose, not a potency): 95%
For compound 4 the middle estimate is 45 percentage points below the measured one, outside the stated range (above it).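

In this assay the same added methyl does not carry over from one core to the other at a constant size: the same change on two cores in this assay, a number 5 percentage points lower (within the scatter) from compound 1 to compound 2 and a number 40 percentage points higher (beyond the scatter) from compound 3 to compound 4, 45 percentage points apart, beyond the scatter of two such steps

Read on its own, the new step is a number 40 percentage points higher from compound 3 to compound 4 (beyond the scatter), so a step taken on the core of compound 1 cannot stand in for this one. What this does not show is whether the core or the place accounts for the gap, since the place differs along with the core: one is a saturated chain carbon three bonds along the chain from an aromatic carbon, the other a saturated chain carbon bound to a nitrogen on an aromatic ring, and with one pair on each core the two cannot be separated.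

The compounds shown leave open whether the read-out keeps rising along the chain on the nitrogen, as with propylamino or butylamino in place of ethylamino. Going by these compounds, a branched isopropylamino group and a free amino group in place of methylamino also remain open.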